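The compounds below may be only part of what the source reports. "The series", "measured", "known", "first", "only" and "open" are said of these compounds alone.

Measured compounds in a functional assay on SH-SY5Y cells (Homo sapiens), read by MTT assay, with a stated time of 24 h; on this read-out higher numbers stand for an effect only at larger amounts of compound and lower numbers for an effect already at smaller amounts:
Compound 1 `COc1ccccc1NC(=O)CN(c1cc(Cl)ccc1OC)S(=O)(=O)c1ccccc1` gives 15500 nM.
Compound 2 `COc1ccc(Cl)cc1N(CC(=O)NC1CCCCC1)S(=O)(=O)c1ccccc1` gives 17600 nM.
Compound 3 `COc1ccc(NC(=O)CN(c2cc(Cl)ccc2OC)S(=O)(=O)c2ccccc2)cc1` gives 16200 nM.

Compound 3 stands second highest of the three numbers, with compound 1 nearest and compound 2 furthest; both gaps are within the scatter, so the three compounds are not separated in this assay. Compound 4 `COc1ccc(Cl)cc1N(CC(=O)Nc1ccc([N+](=O)[O-])cc1)S(=O)(=O)c1ccccc1` differs from compound 3 by nitro in place of methoxy on an aromatic carbon. The change sits on the group carried by the amide-type nitrogen, and all three measured steps alter that same group: a 1.0-fold higher number from compound 1 to compound 3 (0.02 log units; within the scatter), a 1.1-fold lower number from compound 2 to compound 3 (0.04 log units; within the scatter) and a 1.1-fold higher number from compound 1 to compound 2 (0.06 log units; within the scatter). None of them moved the number beyond the scatter, whether the group was 2-methoxyphenyl, 4-methoxyphenyl or cyclohexyl. Nitro in place of methoxy on that aromatic carbon has no measured counterpart, so the expectation rests only on the flatness seen so far across this group. Compound 4 is therefore expected to show no step beyond the scatter, a 1.0-fold lower number from compound 3 to compound 4 (0.01 log units; within the scatter). The estimate for compound 4 in this assay is 16000 nM, with a range from 8000 nM to 32000 nM.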

Compound 4, half-maximal effective concentration: 8210 nM
Compound 4: middle estimate off by 1.9-fold (0.29 log units), on the high side; the measured number falls inside the stated range.
By their numbers in this assay, from the lowest: compounds 4, 1, 3 and 2 (each within the scatter of the next, the first and the last beyond it).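

In this assay, within the data shown here, the group on the amide-type nitrogen looked flat across the earlier compounds, and 4-nitrophenyl now gives the first step beyond the scatter, though only a modest one: a 2.1-fold lower number from compound 2 to compound 4 (0.33 log units; beyond the scatter) against cyclohexyl. The other two steps, a 2.0-fold lower number from compound 3 to compound 4 (0.30 log units; within the scatter) and a 1.9-fold lower number from compound 1 to compound 4 (0.28 log units; within the scatter), stay within the scatter, so compound 4 is separated from compound 2 alone, and nitro in place of methoxy on this aromatic carbon cannot yet be called a real shift. No measurement at hand explains the step.

As far as these compounds go, whether an amine or a carboxylic acid on that aromatic carbon would track with compound 4 or with compound 3 remains open. Also open, from the compounds shown here alone, is how far the numbers depend on the rest of the shared core, which is identical in all four compounds.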